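Fluorophenyl variation at the core and oral exposure

A few compounds are considered here, and "the series" means these few. Any claim that something is new, unique, unknown or untested is made for them only; others in the source may bear on it.

Measured compounds in an ADME assay on the whole organism (Mus musculus, strain Swiss Webster) for pharmacokinetics, read by LC-MS, at a dose of 50 mg/kg by the oral route; on this read-out lower numbers stand for lower exposure and higher numbers for higher exposure at the dose given:
compound 1, `O=C(Nc1ccc(F)c(-c2nc3ncc(-c4ccc(F)c(F)c4)cc3[nH]2)c1)N1CCCC1`, 6670 nM
compound 2, `O=C(Nc1ccc(F)c(-c2nc3ncc(-c4cc(F)ccc4F)cc3[nH]2)c1)N1CCCC1`, 2800 nM
compound 3, `O=C(Nc1ccc(F)c(-c2nc3ncc(C(F)(F)F)cc3[nH]2)c1)N1CCCC1`, 1080 nM

Compound 1 gives the highest maximal plasma concentration of the three. Its nearest neighbour is compound 2, reached by a 2.4-fold lower number from compound 1 to compound 2 (0.38 log units; beyond the scatter); the furthest is compound 3, reached by a 6.2-fold lower number from compound 1 to compound 3 (0.79 log units; beyond the scatter). Between the two lower compounds the step is a 2.6-fold lower number from compound 2 to compound 3 (0.41 log units; beyond the scatter).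

Compound 4, `O=C(Nc1ccc(F)c(-c2nc3ncc(-c4cccc(F)c4)cc3[nH]2)c1)N1CCCC1`, differs from compound 1 by hydrogen in place of fluoro on an aromatic carbon. Within the data shown here, none of the measured steps removes a fluoro from this ring: the step from compound 1 to compound 2 moves both fluoro groups to other positions on the ring, and the steps to compound 3 replace the whole ring by trifluoromethyl. Both changes lowered the number by a modest amount. A single fluoro lost from the ring is a smaller alteration than either, so compound 4 is expected to stay near compound 1, with any step more likely downward than upward, and possibly within the scatter.

For compound 4 the expected outcome is 4500 nM, with a range of 2000 nM to 10000 nM.

The expected step from compound 1 is a 1.5-fold lower number from compound 1 to compound 4 (0.17 log units; within the scatter).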

Compound 4, maximal plasma concentration: 7000 nM
Estimate against measurement, compound 4: 1.6-fold (0.19 log units) below, within the range that was stated.
By their numbers in this assay, from the lowest: compound 3; then compound 2; then compounds 1 and 4 (each within the scatter of the next).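

In this assay, removing the fluoro that stands ortho to a fluoro group and para to a large group gives a 1.0-fold higher number from compound 1 to compound 4 (0.02 log units; within the scatter), so on this read-out the 3,4-difluorophenyl and 3-fluorophenyl groups cannot be told apart, and the second fluoro of compound 1 is not needed to hold the high maximal plasma concentration. The 3-fluorophenyl group also keeps the distance from the two lower compounds, with a 2.5-fold higher number from compound 2 to compound 4 (0.40 log units; beyond the scatter) and a 6.5-fold higher number from compound 3 to compound 4 (0.81 log units; beyond the scatter), which shows that the number of fluoro groups on the ring does not by itself set the value: compound 4, with one fluoro, stands clear of compound 2, with two. No supporting measurement bears on why these steps take this size.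

As far as these compounds go, it remains open whether the last fluoro can also go, leaving plain phenyl, and whether a methoxy group, a nitrile or an amine on this ring would hold the value of compound 4. From the compounds shown here alone, with one read-out at one oral dose, it is also open whether the level values of compound 1 and compound 4 extend to other measures of exposure.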